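The source may report more compounds than this note shows. Statements on the series, on what has been measured and on what is new or still open speak of the compounds shown alone.

Within the data shown here, compound 3 `O=C(Nc1c(C(O)(C(F)(F)F)C(F)(F)F)ccc2ccccc12)c1ccccc1Cl` stands second highest of the three numbers measured so far in an assay on LtK cells with ATP-sensitive inward rectifier potassium channel 11 (Homo sapiens) as the target (on this read-out lower numbers stand for an effect already at smaller amounts and higher numbers for an effect only at larger amounts of compound), where compound 3 gives 2040 nM. Compound 1 `O=C(Nc1c(C(O)(C(F)(F)F)C(F)(F)F)ccc2ccccc12)C1CCCC1` gives 495 nM, and compound 2 `O=C(NCCCCCCCl)Nc1c(C(O)(C(F)(F)F)C(F)(F)F)ccc2ccccc12` gives 4840 nM. The steps among these three are all modest: a 9.8-fold higher number from compound 1 to compound 2 (0.99 log units; beyond the scatter), a 4.1-fold higher number from compound 1 to compound 3 (0.62 log units; beyond the scatter), and a 2.4-fold lower number from compound 2 to compound 3 (0.38 log units; beyond the scatter). Compound 4 `O=C(Nc1c(C(O)(C(F)(F)F)C(F)(F)F)ccc2ccccc12)c1cccc(C(F)(F)F)c1` has not yet been measured. It differs from compound 3 in one place: 3-(trifluoromethyl)phenyl in place of 2-chlorophenyl on a carbonyl carbon. Among the measured compounds shown here, none of the measured steps exchanges one aryl group for another on the carbonyl carbon, so no step bears on this change directly; the two steps of a 4.1-fold higher number from compound 1 to compound 3 (0.62 log units; beyond the scatter) and a 2.4-fold lower number from compound 2 to compound 3 (0.38 log units; beyond the scatter) show only that replacing the group on the carbonyl carbon has moved the number by modest amounts. With no closer guide, the expected step of a 1.4-fold lower number from compound 3 to compound 4 (0.13 log units; within the scatter) is small, near the scatter, with no firm direction. Compound 4 is therefore estimated at 1500 nM, with a range from 400 nM to 6000 nM.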

Compound 4, half-maximal effective concentration: 84 nM
Estimate against measurement, compound 4: 18-fold (1.25 log units) above; measured number outside the range, below it.
By their numbers in this assay, from the lowest: compound 4; then compound 1; then compound 3; then compound 2.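

In this assay, among these compounds, exchanging one aryl group for another on the carbonyl carbon gives a 24-fold lower number from compound 3 to compound 4 (1.39 log units; beyond the scatter), so the choice of aryl group here can move the number more than the earlier steps at this place did. The aryl compounds also fall on either side of the cyclopentyl compound 1: compound 3 lies above it, whereas a 5.9-fold lower number from compound 1 to compound 4 (0.77 log units; beyond the scatter) places compound 4 below it, and a 58-fold lower number from compound 2 to compound 4 (1.76 log units; beyond the scatter) sets the 3-(trifluoromethyl)phenyl group far apart from the (6-chlorohexyl)amino group. No measurement shown explains the size of this change.

The names of compound 3 and compound 4 differ in both the substituent and its ring position, and the compounds shown do not separate these two changes. On these data alone, how a phenyl ring bearing a nitrile or a carboxylic acid, or a pyridine ring in place of phenyl, would read remains open.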